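Benzofuran in place of the azabicycle on the urea series

The source may report more compounds than this note shows. Statements on the series, on what has been measured and on what is new or still open speak of the compounds shown alone.

Among the measured compounds shown here, compound 3 `CC(C)(C)c1cc(NC(=O)Nc2ccc(-c3cn4ncccc4n3)cc2)no1` sits second highest among the three measured members in a functional assay on MV4-11 cells (Homo sapiens) for cytotoxicity, read by MTT assay, with a stated time of 72 h (a higher number here means a weaker inhibitor, a lower number a stronger inhibitor), giving 59.1 nM. Compound 1 `CC(C)(C)c1cc(NC(=O)Nc2ccc(-c3cn4ccccc4n3)cc2)no1` gives 3.09 nM and compound 2 `CC(C)(C)c1cc(NC(=O)Nc2ccc(-c3cn4cccnc4n3)cc2)no1` gives 171 nM. The measured steps of a 55-fold higher number from compound 1 to compound 2 (1.74 log units; beyond the scatter) and a 19-fold higher number from compound 1 to compound 3 (1.28 log units; beyond the scatter) show that adding a nitrogen to the six-membered ring raised the number strongly, while a 2.9-fold lower number from compound 2 to compound 3 (0.46 log units; beyond the scatter) was modest. Compound 4 `CC(C)(C)c1cc(NC(=O)Nc2ccc(-c3cc4ccccc4o3)cc2)no1` carries the change (a group of 9 heavy atoms (8 carbon, 1 oxygen; one five-membered aromatic ring with 1 hetero atom, one six-membered aromatic ring of carbon only) in place of a group of 9 heavy atoms (6 carbon, 3 nitrogen; one five-membered aromatic ring with 2 hetero atoms, one six-membered aromatic ring with 2 hetero atoms), on an aromatic carbon), placed on an aromatic carbon of a six-membered aromatic ring of carbon only, para to a large group; all nitrogens of the bicycle leave. By analogy to compound 1, the number for compound 4 is expected to fall, giving an estimated 3.9-fold lower number from compound 3 to compound 4 (0.60 log units; beyond the scatter). Compound 4 is therefore estimated at 15 nM, within 3 nM to 80 nM.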

Compound 4, half-maximal inhibitory concentration: 195 nM
The estimate for compound 4 lay 13-fold (1.11 log units) below the measured number; the whole stated range lies below it.
By their numbers in this assay, from the lowest: compound 1; then compound 3; then compounds 2 and 4 (each within the scatter of the next).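

In this assay the 1-benzofuran-2-yl group does not return the series to the level of compound 1 (a 63-fold higher number from compound 1 to compound 4 (1.80 log units; beyond the scatter)), so removing all nitrogens from the bicycle does not by itself restore the low number. It also gives no gain over the bicycle of compound 3 (a 3.3-fold higher number from compound 3 to compound 4 (0.52 log units; beyond the scatter)) and leaves compound 4 level with compound 2 (a 1.1-fold higher number from compound 2 to compound 4 (0.06 log units; within the scatter)). No supporting data explain these steps.

The compounds shown leave open whether the loss of the nitrogens or the entry of the oxygen drives these steps. They also leave open how an amine or a methoxy group on the bicycle of compound 1 would move the number.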